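This account rests on a few compounds, and the source may have more. Where it says the series, first, only, none or still open, it means among the compounds named here.

In an ADME assay on Huh-7 cells (Homo sapiens) for cytotoxicity (a lower number here means that less compound is tolerated, a higher number that more compound is tolerated), compound 2, `Cc1ccccc1-c1nn(-c2ccccc2Cl)cc1CNCCN1CCN(C)CC1`, reaches only a limit of the assay, > 20000 nM. Compound 3, `Cc1ccc(-c2nn(-c3ccc(F)cc3F)cc2CNCCN2CCN(C)CC2)cc1`, likewise gives only a limit, > 20000 nM. Compound 1, `CN1CCN(CCNCc2cn(-c3ccc(F)cc3F)nc2-c2ccc(OC(F)(F)F)cc2)CC1`, gives 18000 nM. Among the compounds with values here, the single measured step in this assay, an at least 1.1-fold higher number from compound 1 to compound 3 (0.04 log units; that floor lies within the scatter), runs into the limit, as the limit of > 20000 nM in this assay, at which 2 of the 3 values shown sit, shows. Compound 4, `Cc1ccccc1-c1nn(-c2ccc(Br)cc2)cc1CNCCN1CCN(C)CC1`, differs from compound 2 by 4-bromophenyl in place of 2-chlorophenyl on an aromatic nitrogen. Within the data shown here, no measured step touches that position, so direct guidance is missing; the step from compound 1 to compound 3 concerns another position and lies within the scatter. Compound 4 is therefore expected to remain near the limit of this assay, with an expected step of a number no higher from compound 2 to compound 4 (the limit leaves the size open), none beyond the scatter. The estimate for compound 4 is 20000 nM, ranging from 10000 nM to 40000 nM.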

Compound 4, half-maximal cytotoxic concentration: 9600 nM
The estimate for compound 4 lay 2.1-fold (0.32 log units) above the measured number, outside the stated range (below it).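

In this assay, within the data shown here, the group on the aromatic nitrogen proves able to shift the number, which no earlier compound could show: 4-bromophenyl in place of 2-chlorophenyl gives an at least 2.0-fold lower number from compound 2 to compound 4 (0.31 log units; beyond the scatter). This step is only a floor, and its true size stays unknown, because compound 2 gives a limit and not a number: the limit of > 20000 nM in this assay, at which 2 of the 4 values shown sit.

The change swaps the halogen and moves it around the phenyl ring at once, so the compounds shown cannot separate these two changes. On these data alone, the numbers for 4-chlorophenyl and 2-bromophenyl at this position, which could separate them, remain open.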